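Hydroxy end on the alkyne chain of compound 2

The source may report more compounds than this note shows. Statements on the series, on what has been measured and on what is new or still open speak of the compounds shown alone.

Values in a functional assay on NIH3T3 cells (Mus musculus); a higher number here means that more compound is needed for the effect, a lower number that less compound is needed:
- Compound 1 `Cn1cncc1C(OCc1ccc(C#N)cc1-c1ccccc1)c1ccc(C#N)cc1`: 140 nM
- Compound 2 `CCCCCCC#Cc1cc(C#N)ccc1COC(c1ccc(C#N)cc1)c1cncn1C`: > 0.1 nM, a limit and not a number

Compound 2 stands only at this limit, and no number places it in this assay. Compound 3 `Cn1cncc1C(OCc1ccc(C#N)cc1C#CCCCCO)c1ccc(C#N)cc1` differs from compound 2 by hydroxy in place of ethyl on a saturated chain carbon, four bonds along the chain from a triple-bonded carbon. Going by the values given here, the only measured step, a step that the limit leaves unreadable from compound 1 to compound 2, puts oct-1-yn-1-yl in place of phenyl on an aromatic carbon, and its size cannot be read. It gives no size or direction for the new change. Among the compounds with values here, the expectation therefore rests on compound 1 at 140 nM, the only number. The estimated step is a step that the limit leaves unreadable from compound 2 to compound 3, with no direction supported by measurement. For compound 3 the expected value is 150 nM, with an estimated range of 20 nM to 1000 nM.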

Compound 3, half-maximal effective concentration: 20.9 nM
For compound 3 the middle estimate is 7.2-fold (0.86 log units) above the measured one; the range from low to high includes it.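

In this assay, 6-hydroxyhex-1-yn-1-yl in place of phenyl on the aromatic carbon gives a 6.7-fold lower number from compound 1 to compound 3 (0.83 log units; beyond the scatter), beyond the usual scatter. Going by these compounds alone, compound 3, at 20.9 nM, is thus the first alkyne-bearing compound with a readable number, and it shows that the position accepts an alkyne chain with a hydroxy end in place of phenyl without a rise in the number. Compound 2 has only a limit and not a number, so the step from it to compound 3 cannot be read: the limit of > 0.1 nM in this assay, at which 1 of the 3 values shown sits.

The compounds shown therefore do not separate the contribution of the hydroxy end from that of the alkyne chain itself. From the compounds shown here alone, how an amine or a carboxylic acid at the chain end, or a longer chain carrying the hydroxy, would read in this assay also stays open.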